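From 4-acetylphenyl to 3-amino-4-methoxyphenyl on the shared core

This account rests on a few compounds, and the source may have more. Where it says the series, first, only, none or still open, it means among the compounds named here.

Measured in a functional assay on HeLa cells (Homo sapiens) for inhibition, read by CCK-8 assay, with a stated time of 48 h; on this read-out higher numbers stand for weaker inhibition and lower numbers for stronger inhibition:
Compound 1 `C=Cc1ccc(-c2cc3nccc(-c4cc(OC)c(OC)c(OC)c4)n3n2)cc1`: 882 nM
Compound 2 `COc1cc(-c2ccnc3cc(-c4ccc(C(C)=O)cc4)nn23)cc(OC)c1OC`: 1810 nM

Compound 2, at 1810 nM, holds the higher of the two numbers, which makes it the weaker inhibitor of the pair. Compound 3 `COc1ccc(-c2cc3nccc(-c4cc(OC)c(OC)c(OC)c4)n3n2)cc1N` has not yet been measured. It keeps the core of compound 2 and carries 3-amino-4-methoxyphenyl in place of 4-acetylphenyl on an aromatic carbon. Among the measured compounds shown here, only one measured step bears on this change, a 2.1-fold higher number from compound 1 to compound 2 (0.31 log units; beyond the scatter), a modest one with acetyl in place of vinyl. For the measured compounds named here, the new change swaps the whole group, so no measured step covers it and the range must stay wide. A move toward stronger inhibition in this assay, larger than that measured step, is expected: a 9.1-fold lower number from compound 2 to compound 3 (0.96 log units; beyond the scatter). Compound 3 is estimated at 200 nM, with an expected range of 25 nM to 1500 nM.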

Compound 3, half-maximal inhibitory concentration: 283 nM
The estimate for compound 3 lay 1.4-fold (0.15 log units) below the measured number; low and high end bracket the measured number.
By their numbers in this assay, from the lowest: compound 3; then compound 1; then compound 2.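

In this assay, the two earlier compounds showed only a modest spread at this aromatic carbon of the five-membered aromatic ring, and 3-amino-4-methoxyphenyl extends it downward, with a 6.4-fold lower number from compound 2 to compound 3 (0.81 log units; beyond the scatter) against 4-acetylphenyl and a 3.1-fold lower number from compound 1 to compound 3 (0.49 log units; beyond the scatter) against 4-vinylphenyl. Both steps lie beyond the scatter, so this position responds to a change of the whole group, and the entering group, which brings a hydrogen-bond donor that 4-acetylphenyl lacks, gives the lowest number of the three. Nothing at hand accounts for this difference.

The amine and the methoxy group arrive together, so the compounds shown cannot say what each contributes alone. On these data alone, a phenyl group carrying only one of them would separate the two, and whether a hydroxyl group could stand in for the amine also remains open.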